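The compounds below may be only part of what the source reports. "The series", "measured", "known", "first", "only" and "open" are said of these compounds alone.

The measured compounds and their values in an ADME assay on HEK293 cells for agonist activity at Toll-like receptor 8 (Homo sapiens), read by a luciferase reporter, with a stated time of 6 h; a lower number here means that less compound is needed, a higher number that more compound is needed for the effect:

compound 1, `CCCCNc1nc(N)nc2cccc(OCc3ccc(CO)cc3OC)c12`: > 25 uM.
compound 2, `CCCCNc1nc(N)nc2cccc(C(=O)N[C@@H](C)c3ccccc3)c12`: > 25 uM.
compound 3, `CCCCNc1nc(N)nc2cccc(C(=O)N[C@@H](C)c3cccc(OC)c3)c12`: > 25 uM.

For compound 1 the value is a limit of the assay, not a number. The same holds for compound 2, whose value is likewise a limit. Compound 3 also stands only at a limit, namely (the limit of > 25 uM in this assay, at which 3 of the 3 values shown sit), so on the numbers shown nothing sets it apart from the other two. Among the measured compounds shown here, the one step between measured compounds that differ in a single place, a step that the two limits leave unreadable from compound 2 to compound 3, cannot be read, since both of its ends are limits.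

Compound 4, `CCCCNc1nc(N)nc2cccc(C(=O)N[C@@H](C)c3ccccc3OC)c12`, is not yet measured in this assay. It differs from compound 3 in one place: 2-methoxyphenyl in place of 3-methoxyphenyl on a saturated chain carbon bound to an amide-type nitrogen and a saturated chain carbon. For the measured compounds named here, no measured step bears on this change, and the only step at hand gives no size at all. With compound 3 at a limit and nothing to suggest a move away from it, the expected step is a number no higher from compound 3 to compound 4 (the limit leaves the size open), none beyond the scatter. Compound 4 is therefore estimated to stay at the limit, at 25 uM, within a range from 10 uM to 100 uM.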

Compound 4, minimum effective concentration: > 25 uM
Compound 4 was reported as a limit; the forecaster's own chance of this, stated with the estimate: 85%; the middle value sits exactly at the limit.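

In this assay compound 4 gives > 25 uM as a limit of the assay, not a number. Among the compounds shown here, no step among compound 2, compound 3 and compound 4 can be read: the limit of > 25 uM in this assay, at which 4 of the 4 values shown sit. The compounds shown leave open whether 2-methoxyphenyl, 3-methoxyphenyl or the unsubstituted phenyl differ at all in minimum effective concentration.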